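Swapping phenyl for benzyl on a hydroxamic acid inhibitor

The source may report more compounds than this note shows. Statements on the series, on what has been measured and on what is new or still open speak of the compounds shown alone.

Of the compounds shown here, three have so far been measured in an assay on isolated protein for inhibition of histone deacetylase HD1B (Zea mays); a lower number here means a stronger inhibitor, a higher number a weaker inhibitor. Compound 1 `O=C(CCCSc1nc(O)cc(CCc2ccccc2)n1)NO` gives 170 nM in this assay. Compound 2 `O=C(/C=C/c1cccc(CSc2nc(O)cc(-c3ccccc3)n2)c1)NO` gives 64 nM. Compound 3 `CCC(c1ccccc1)c1cc(O)nc(SCCCCCC(=O)NO)n1` gives 31 nM. Compound 2 thus holds the second highest of the three numbers: compound 3 lies nearest to it, separated by more than the scatter, and compound 1 lies furthest, also beyond the scatter.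

Compound 4 `O=C(/C=C/c1cccc(CSc2nc(O)cc(Cc3ccccc3)n2)c1)NO` is the next compound to be measured. It differs from compound 2 in one place: benzyl in place of phenyl on an aromatic carbon. For the measured compounds named here, no pair of measured compounds differs in only this way, so there is no measured step to lean on. Compounds 1 and 3 carry their phenyl on other links to the shared core, together with further changes, and their numbers sit on either side of compound 2. A change no larger than the scatter is expected. For compound 4 the estimate is 70 nM, with a range from 25 nM to 200 nM. The expected step of a 1.1-fold higher number from compound 2 to compound 4 (0.04 log units; within the scatter) stays within the scatter.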

Compound 4, half-maximal inhibitory concentration: 42 nM
Beside the measured number, compound 4's estimate is 1.7-fold (0.22 log units) above it; measured number inside the range.
By their numbers in this assay, from the lowest: compounds 3, 4 and 2 (each within the scatter of the next, the first and the last beyond it); then compound 1.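

In this assay, for the compounds shown here, benzyl in place of phenyl on this aromatic carbon gives a 1.5-fold lower number from compound 2 to compound 4 (0.18 log units; within the scatter), the first direct reading of this swap with the rest of the molecule held constant. The two compounds cannot be told apart, so at this position, growing the group from 6 to 7 heavy atoms brings no measurable change in inhibition. The data offer no explanation of why the two groups read alike.

Going by these compounds, it remains open whether a group of a different kind at this aromatic carbon, such as an amine or a carboxylic acid, would read the same as these carbon-only aromatic groups. On these data alone, it is also open whether benzyl and phenyl would read alike on the different chains carried by compound 1 and compound 3.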